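Amide nitrogen substitution in the shared core series

This account rests on a few compounds, and the source may have more. Where it says the series, first, only, none or still open, it means among the compounds named here.

Measured compounds:
compound 1 `CN(C)C(=O)Cn1c(-c2ccc(Br)o2)nc2cccnc21` gives 100 mg/kg
compound 2 `CNC(=O)Cn1c(-c2ccc(Cl)cc2)nc2cccnc21` gives 12.5 mg/kg

Both numbers come from a functional assay on the whole organism with Mus musculus as the target; on this read-out lower numbers stand for an effect already at smaller amounts and higher numbers for an effect only at larger amounts of compound. For the measured compounds named here, compound 2 stands at the lower of the two numbers; compound 1 lies far above it, beyond the scatter, but the two compounds differ in more than one place, so no single step between them can be drawn from them.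

The next compound, compound 3 `CN(C)CCCNC(=O)Cn1c(-c2ccc(Cl)cc2)nc2cccnc21`, has not yet been measured in this assay. It differs from compound 2 by 2-(dimethylamino)ethyl in place of hydrogen on a saturated chain carbon bound to an amide-type nitrogen. Going by the values given here, no measured pair shows this change, so the direction rests on no data; the expected step is small, toward higher numbers, and close to the scatter, a 1.6-fold higher number from compound 2 to compound 3 (0.20 log units; within the scatter). For compound 3 the value in this assay is estimated at 20 mg/kg, with a range from 6 mg/kg to 70 mg/kg.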

Compound 3, dose for half-maximal effect: 64 mg/kg
The estimate for compound 3 lay 3.2-fold (0.51 log units) below the measured number; low and high end bracket the measured number.
By their numbers in this assay, from the lowest: compound 2; then compounds 3 and 1 (each within the scatter of the next).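

In this assay, for the compounds shown here, 2-(dimethylamino)ethyl in place of hydrogen on a saturated chain carbon bound to an amide-type nitrogen gives a 5.1-fold higher number from compound 2 to compound 3 (0.71 log units; beyond the scatter), the first single-place step. Read one bond further out, the change is methyl to 3-(dimethylamino)propyl, so this position is sensitive to the group it carries, and this extension moves the number upward while an effect remains measurable. No data shown bear on the reason for this step.

The compounds shown do not separate the contribution of the added chain length from that of the terminal dimethylamino group; a plain propyl or a 3-hydroxypropyl at this place would make that distinction. On these data alone, whether a shorter chain ending in the same amine, or a terminal piperidine, behaves alike also remains open.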